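A Third Methoxy Group on the Shared Core

The source may report more compounds than this note shows. Statements on the series, on what has been measured and on what is new or still open speak of the compounds shown alone.

Compound 1 `COc1ccc(/C=C/C2CC(=O)C=CO2)cc1`: 239 uM
Compound 2 `COc1ccc(/C=C/C2CC(=O)C=CO2)cc1OC`: 146 uM

Of the compounds shown here, two have been measured in a functional assay on NCI/ADR cells (Homo sapiens) for inhibition, read by sulforhodamine B assay, with a stated time of 48 h; on this read-out lower numbers stand for stronger inhibition of growth and higher numbers for weaker inhibition of growth. Compound 2 gives the lower of the two numbers, but its nearest neighbour, compound 1, differs from it only by a 1.6-fold lower number from compound 1 to compound 2 (0.21 log units; within the scatter), so the two values cannot be told apart.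

Compound 3 `COc1cc(/C=C/C2CC(=O)C=CO2)cc(OC)c1OC` has not yet been measured. It differs from compound 2 by methoxy in place of hydrogen on an aromatic carbon. Within the data shown here, the one step that bears on this change is the same kind of change, from compound 1 to compound 2, and it stayed within the scatter. No other comparison is available. The expectation for compound 3 is therefore a step of about a 1.3-fold lower number from compound 2 to compound 3 (0.10 log units; within the scatter) in this assay, that is, no real change beyond the scatter, with perhaps a slight drift toward a lower number. Compound 3 is expected to give about 115 uM, within a range of 45 uM to 290 uM.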

Compound 3, concentration for growth inhibition (reported as GI): 223 uM
For compound 3 the middle estimate is 1.9-fold (0.29 log units) below the measured one; low and high end bracket the measured number.
By their numbers in this assay, from the lowest: compounds 2, 3 and 1 (each within the scatter of the next).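

In this assay, methoxy in place of hydrogen on this aromatic carbon, ortho to a methoxy group and meta to a group of 9 heavy atoms, gives a 1.5-fold higher number from compound 2 to compound 3 (0.18 log units; within the scatter), so the position accepts the added group with no change that can be told from the scatter. The earlier step, a 1.6-fold lower number from compound 1 to compound 2 (0.21 log units; within the scatter), was also within the scatter, and with this second step neither compound pair shows a real effect of this kind of change in either direction. Nothing measured here offers an explanation for these results.

The compounds shown carry only methoxy or hydrogen on the aromatic ring, so it remains open whether an amine, a carboxylic acid or a longer alkoxy chain at this position would move the number beyond the scatter. Going by these compounds, it also remains open whether any such group would matter on a different place of the shared core.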